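Cytotoxicity in the lactam series: the methylsulfonyl analogue

The compounds below may be only part of what the source reports. "The series", "measured", "known", "first", "only" and "open" are said of these compounds alone.

Three members of the series have been run in a functional assay on HEK293 cells (Homo sapiens) for cytotoxicity; a lower number here means that less compound is tolerated, a higher number that more compound is tolerated. Compound 1 `COc1ccc([C@H]2CC(=O)N(Cc3cccc([N+](=O)[O-])c3)C2)cc1OC1CCCC1` reaches only the limit of the assay there, > 10000 nM. Compound 2 `COc1ccc([C@H]2CC(=O)N(c3ccc(N)cc3)C2)cc1OC1CCCC1` likewise gives in this assay only a limit, > 10000 nM. Compound 3 `COc1ccc([C@H]2CC(=O)N(c3ccccc3C)C2)cc1OC1CCCC1` also stands at the limit in this assay, > 10000 nM. Because of the limit of > 10000 nM in this assay, at which 3 of the 3 values shown sit, none of the steps between these three can be read: a step that the two limits leave unreadable from compound 1 to compound 2, a step that the two limits leave unreadable from compound 1 to compound 3 and a step that the two limits leave unreadable from compound 2 to compound 3 remain without a size. Going by the values given here, compound 3 therefore stands at the limit together with every other value shown, and no member of the series has yet returned a number in this assay.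

Compound 4 `COc1ccc([C@H]2CC(=O)N(c3ccc(S(C)(=O)=O)cc3)C2)cc1OC1CCCC1` differs from compound 3 by 4-(methylsulfonyl)phenyl in place of 2-methylphenyl on an amide-type nitrogen in a ring. Among the compounds with values here, no measured step bears on this change with a readable size, so the only evidence is that every substituent tried so far on the same nitrogen has left the value at the limit. Compound 4 is therefore expected to sit at 20000 nM in this assay, with a range from 8000 nM to 60000 nM. The expected step that the limit leaves unreadable from compound 3 to compound 4 is thus none beyond the scatter, and most likely the assay will again report only a limit.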

Compound 4, half-maximal cytotoxic concentration: > 10000 nM
Compound 4: only a limit was reported; the forecaster's own chance of this, stated with the estimate: 85%; the middle value lies beyond the limit too.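

In this assay compound 4 also gives only a limit, > 10000 nM. No step linking compound 4 to compound 1, compound 2 or compound 3 can be read, because all the values share one limit: the limit of > 10000 nM in this assay, at which 4 of the 4 values shown sit.

The compounds shown leave open what number any member of the series would return in this assay, and whether the substituent on the amide-type nitrogen affects it.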